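This account rests on a few compounds, and the source may have more. Where it says the series, first, only, none or still open, it means among the compounds named here.

Two compounds of this series carry results in a functional assay on PC-9 cells (Homo sapiens) for inhibition, read by MTT assay, with a stated time of 72 h; a higher number here means a weaker inhibitor, a lower number a stronger inhibitor. Among the compounds with values here, compound 1 `Cc1cc(Nc2cc(-c3ccccc3)[nH]n2)n2nc(SCc3cccc(Br)c3)nc2n1` gives 8900 nM, the only numerical value in hand. Compound 2 `Cc1ccc(Cn2ccc(Nc3cc(C)nc4nc(SCc5ccc(Br)cc5)nn34)n2)cc1` returns only a limit, > 50000 nM, and no number (the limit of > 50000 nM in this assay, at which 1 of the 2 values shown sits). Compound 3 `Cc1cc(Nc2cc(-c3ccccc3)[nH]n2)n2nc(SCC3CC3)nc2n1` is the unmeasured member; it differs from compound 1 by cyclopropyl in place of 3-bromophenyl on a saturated chain carbon bound to a sulfur. Within the data shown here, no measured pair tells what this change does, so the expectation rests on compound 1 alone: a modest loss of potency is expected, and the estimated step of a 1.7-fold higher number from compound 1 to compound 3 (0.23 log units; within the scatter) is set accordingly. Compound 3 is expected to give 15000 nM, within a range from 5000 nM to 50000 nM.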

Compound 3, half-maximal inhibitory concentration: > 50000 nM
Compound 3 ended at the assay's limit; the forecaster's own chance of this, stated with the estimate: 30%; middle value at least 3.3-fold (0.52 log units) away from the limit.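

In this assay, within the data shown here, cyclopropyl in place of 3-bromophenyl on a saturated chain carbon bound to a sulfur gives an at least 5.6-fold higher number from compound 1 to compound 3 (0.74 log units; beyond the scatter), the first readable step. Among these compounds, at this position, the 3-bromophenyl of compound 1 goes with the only numerical value so far, and cyclopropyl does not retain it. The result for compound 3 is a limit and not a number, so the full size of the step stays unknown: the limit of > 50000 nM in this assay, at which 2 of the 3 values shown sit.

Going by these compounds, whether the loss tracks the bromine or the aromatic ring stays open. A plain benzyl or a 3-chlorobenzyl at this position would separate the two.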